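Swapping the amide cap for a sulfonyl cap on an octadecyl carrier

A few compounds are considered here, and "the series" means these few. Any claim that something is new, unique, unknown or untested is made for them only; others in the source may bear on it.

Three thienoyl-capped threonine amides have been measured in a functional assay on A-431 cells (Homo sapiens) for cytotoxicity, read by MTT assay, with a stated time of 48 h; on this read-out lower numbers stand for stronger inhibition and higher numbers for weaker inhibition. Compound 1 `CCCCCCCCNC(=O)[C@@H](NC(=O)c1cccs1)[C@@H](C)O` gives 32200 nM, compound 2 `CCCCCCCCCCCCCCNC(=O)[C@@H](NC(=O)c1cccs1)[C@@H](C)O` gives 26500 nM, and compound 3 `CCCCCCCCCCCCCCCCCCNC(=O)[C@@H](NC(=O)c1cccs1)[C@@H](C)O` gives 33300 nM. Compound 3 stands at the highest number of the three, but its nearest neighbour is compound 1 and its furthest is compound 2, and both gaps lie within the scatter. The steps of a 1.2-fold lower number from compound 1 to compound 2 (0.08 log units; within the scatter), a 1.0-fold higher number from compound 1 to compound 3 (0.01 log units; within the scatter) and a 1.3-fold higher number from compound 2 to compound 3 (0.10 log units; within the scatter) all concern only the length of the saturated chain on the amide nitrogen and none of them exceeds the scatter.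

Compound 4 `CCCCCCCCCCCCCCCCCCNC(=O)[C@@H](NS(=O)(=O)c1ccc(C)cc1)[C@@H](C)O` keeps the octadecyl chain of compound 3 and changes the other end: (4-methylphenyl)sulfonyl in place of (thiophen-2-yl)carbonyl on an amine nitrogen. Among the compounds with values here, no measured step touches this position, so the three chain-length steps bear on it only by showing that this series has so far sat at one level in this assay. The expectation for compound 4 is therefore no step beyond the scatter, a 1.1-fold lower number from compound 3 to compound 4 (0.05 log units; within the scatter), with a wide band for an untested change. Compound 4 is expected to give about 30000 nM, within 10000 nM to 90000 nM.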

Compound 4, half-maximal inhibitory concentration: 34000 nM
Estimate against measurement, compound 4: 1.1-fold (0.05 log units) below; the measured number falls inside the stated range.
By their numbers in this assay, from the lowest: compounds 2, 1, 3 and 4 (each within the scatter of the next).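

Within the data shown here, compound 4 gives the first reading at this end of the molecule: with the octadecyl chain held, (4-methylphenyl)sulfonyl in place of (thiophen-2-yl)carbonyl on an amine nitrogen gives in this assay a step of a 1.0-fold higher number from compound 3 to compound 4 (0.01 log units; within the scatter). The chain-length steps could not show this, but this pair shows that a six-membered aromatic ring of carbon only on a sulfonyl link reads the same in this assay as a five-membered aromatic ring with 1 hetero atom on a carbonyl link, although ring and link both change at once. No measured evidence is at hand to account for the two caps reading alike.

Ring and link change together here, so the compounds shown cannot separate them; a benzoyl cap or a (thiophen-2-yl)sulfonyl cap would each change only one of the two. Also open, as far as these compounds go, is whether this level holds for the sulfonyl cap on an octyl chain, or when an amine or a carboxylic acid is carried on the aromatic ring of the cap.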